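Notes on a small kinase series

The source may report more compounds than this note shows. Statements on the series, on what has been measured and on what is new or still open speak of the compounds shown alone.

Compound 1 `CCOC(=O)c1c(-c2ccc(OC)c(OC)c2)csc1N` gives 100% in an assay on isolated protein for inhibition of protein kinase C zeta type (Homo sapiens), with stated times of 1 h and 2.5 min, tested at 30 uM; on this read-out higher numbers stand for more inhibition at the one concentration tested (going by the name of the read-out) and lower numbers for less inhibition. Compound 2 `COc1ccc(-c2csc(N)c2C(=O)Oc2ccccc2)cc1OC` gives 48%, and compound 3 `CCOC(=O)c1c(-c2cccc(OC)c2)csc1N` gives 82%, so compound 3 stands second of the three measured numbers, below compound 1 and above compound 2. The two measured steps are a number 52 percentage points lower from compound 1 to compound 2 (beyond the scatter) and a number 18 percentage points lower from compound 1 to compound 3 (beyond the scatter).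

Compound 4 `CCOC(=O)c1c(-c2cccc(C(F)(F)F)c2)csc1N` differs from compound 3 by trifluoromethyl in place of methoxy on an aromatic carbon. Among the compounds with values here, the only measured step that touches the same aromatic carbon is a number 18 percentage points lower from compound 1 to compound 3 (beyond the scatter), where methoxy was removed; no measured compound carries trifluoromethyl anywhere. A further change on that aromatic carbon is expected to lower the read-out again, so the step of a number 17 percentage points lower from compound 3 to compound 4 (beyond the scatter) is expected to be modest and downward. Compound 4 is estimated at 65%, with a range from 35% to 90%.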

Compound 4, a percentage reported as inhibition, at one concentration (the size of the read-out at that concentration, not a potency): 30%
Compound 4: the middle estimate sits 35 percentage points above what was measured; the measured number lies below the stated range.
By their numbers in this assay, from the lowest: compound 4; then compound 2; then compound 3; then compound 1.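

At this aromatic carbon, trifluoromethyl in place of methoxy gives a number 52 percentage points lower from compound 3 to compound 4 (beyond the scatter) and so costs more than the removal of a methoxy group, which gave a number 18 percentage points lower from compound 1 to compound 3 (beyond the scatter) earlier in the series. The result shows that the read-out depends strongly on which group occupies this carbon, and that a methoxy group here is far from interchangeable with trifluoromethyl. Nothing available explains the size of this step.

From the compounds shown here alone, how an amine, a carboxylic acid or a longer alkoxy chain would read at this carbon remains open. Also open, going by these compounds, is whether trifluoromethyl would cost as much on the core of compound 1 with its second methoxy group in place.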